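The source may report more compounds than this note shows. Statements on the series, on what has been measured and on what is new or still open speak of the compounds shown alone.

In an in vitro ADME assay on microsomes from liver (Homo sapiens) for pharmacokinetics, read by LC-MS, with a stated time of 10 min, tested at 1 uM (on this read-out lower numbers stand for slow clearance and higher numbers for fast clearance), compound 1 (`CN1C[C@H](C(=O)Nc2ccc(F)cc2)[C@@H](c2ccc(/C=C/C(=O)Nc3ccccc3N)cc2)C1`) gives 5 mL/min/kg, compound 2 (`Cc1ccc(NC(=O)[C@H]2CN(C)C[C@@H]2c2ccc(/C=C/C(=O)Nc3ccccc3N)cc2)cc1`) gives 15 mL/min/kg and compound 3 (`COc1ccc(NC(=O)[C@H]2CN(C)C[C@@H]2c2ccc(/C=C/C(=O)Nc3ccccc3N)cc2)cc1`) gives 14 mL/min/kg. Swapping methyl for methoxy gives a 1.1-fold lower number from compound 2 to compound 3 (0.03 log units; within the scatter), while the swaps away from fluoro give a 3.0-fold higher number from compound 1 to compound 2 (0.48 log units; beyond the scatter) and a 2.8-fold higher number from compound 1 to compound 3 (0.45 log units; beyond the scatter), so compound 3 sits in the upper part of this small range. Compound 4 (`CN1C[C@H](C(=O)Nc2ccc(C(F)(F)F)cc2)[C@@H](c2ccc(/C=C/C(=O)Nc3ccccc3N)cc2)C1`) carries trifluoromethyl in place of methoxy on an aromatic carbon, para to a large group: trifluoromethyl in place of methoxy on an aromatic carbon. Going by the values given here, no trifluoromethyl compound has been measured yet, but the new group contains fluorine, as does the fluoro group of compound 1 at 5 mL/min/kg, so a partial move toward that value seems reasonable. The expected change, toward lower numbers and no larger than the scatter, is a 1.6-fold lower number from compound 3 to compound 4 (0.19 log units; within the scatter). For compound 4 the estimated clearance is 9 mL/min/kg, with an expected range of 4 mL/min/kg to 20 mL/min/kg.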

Compound 4, clearance: 6 mL/min/kg
Compound 4: the middle estimate sits 1.5-fold (0.18 log units) above what was measured, within the range that was stated.
By their numbers in this assay, from the lowest: compounds 1 and 4 (each within the scatter of the next); then compounds 3 and 2 (each within the scatter of the next).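

Placed para to a large group, trifluoromethyl gives a 2.3-fold lower number from compound 3 to compound 4 (0.37 log units; beyond the scatter) and a 2.5-fold lower number from compound 2 to compound 4 (0.40 log units; beyond the scatter) in clearance, whereas a 1.2-fold higher number from compound 1 to compound 4 (0.08 log units; within the scatter) leaves it on a par with fluoro. Among these four compounds, the two fluorine-bearing groups therefore sit together at the low end, and methyl and methoxy sit together at the high end. Nothing available explains this split.

On these data alone, it remains open whether the split extends to other groups at this place. A chloro group, a nitrile or an amine could fall with either pair.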